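The source may report more compounds than this note shows. Statements on the series, on what has been measured and on what is new or still open speak of the compounds shown alone.

Working notes on the series in a functional assay on the whole organism with Rattus norvegicus as the target; on this read-out higher numbers stand for an effect only at larger amounts of compound and lower numbers for an effect already at smaller amounts. Compound 1 (`CCOC(=O)C(=O)Nc1cccc(OC)c1C#N`) gives 5.3 mg/kg, compound 2 (`CCOC(=O)C(=O)Nc1cccc(N)c1C#N`) gives 0.05 mg/kg, and compound 3 (`CCOC(=O)C(=O)Nc1cccc(C(=O)OC)c1C#N`) gives 1.2 mg/kg, the middle of the three numbers. The next change leads to compound 4 (`CCOC(=O)C(=O)Nc1cccc(F)c1C#N`): fluoro in place of methoxycarbonyl on an aromatic carbon, ortho to a cyano group. All measured steps concern this carbon. Among the groups without amino, the change is modest, a 4.4-fold lower number from compound 1 to compound 3 (0.65 log units; beyond the scatter). Compound 2 stands apart, with a 110-fold lower number from compound 1 to compound 2 (2.03 log units; beyond the scatter) and a 24-fold higher number from compound 2 to compound 3 (1.38 log units; beyond the scatter), both large. Among the compounds with values here, no fluoro compound has been measured, so the expectation is weakly grounded. The expected change is small, a 1.3-fold higher number from compound 3 to compound 4 (0.10 log units; within the scatter), not beyond the scatter. For compound 4 the estimate is 1.5 mg/kg, with an expected range of 0.3 mg/kg to 7 mg/kg.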

Compound 4, dose for half-maximal effect: 1.2 mg/kg
Compound 4: middle estimate off by 1.3-fold (0.10 log units), on the high side, and the stated range covers the measured number.
By their numbers in this assay, from the lowest: compound 2; then compounds 3 and 4 (each within the scatter of the next); then compound 1.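

In this assay, a single fluorine takes the place of methoxycarbonyl at this carbon with no shift in the read-out (no change at the digits printed from compound 3 to compound 4 (within the scatter)), so the two groups cannot be told apart here despite their difference in size. Fluoro still stands well apart from amino (a 24-fold higher number from compound 2 to compound 4 (1.38 log units; beyond the scatter)) and from methoxy (a 4.4-fold lower number from compound 1 to compound 4 (0.65 log units; beyond the scatter)), which leaves amino alone at the low end among these four groups. No measurement available here explains these steps. Open, going by these compounds, is whether the low number of compound 2 persists with a methylamino or dimethylamino group at this carbon, and whether a hydroxyl group falls nearer amino or fluoro.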